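The source may hold more compounds than are shown below. What is called first, only, known or untested is meant among the compounds shown, and "the series" means these compounds.

The measured compounds are:

compound 1, `Cc1cc(NC(=O)Nc2ccc(N(C)C)cc2)c2ccccc2n1`; in an ADME assay on HEK293 cells (Homo sapiens) for cytotoxicity, with a stated time of 72 h (on this read-out higher numbers stand for an effect only at larger amounts of compound and lower numbers for an effect already at smaller amounts), compound 1 gives > 25000 nM, which is a limit of the assay and not a number.

compound 2, `Cc1cc(NC(=O)Nc2ccc(C(F)(F)F)cc2)c2ccccc2n1`; in this assay compound 2 gives 25000 nM.

compound 3, `Cc1cc(NC(=O)Nc2cccc(C(F)(F)F)c2)c2ccccc2n1`; in this assay compound 3 gives 16000 nM.

Compound 4, `Cc1cc(NC(=O)Nc2cccc(N(C)C)c2)c2ccccc2n1`, has not yet been tested in this assay. It differs from compound 3 in one place: dimethylamino in place of trifluoromethyl on an aromatic carbon. The same kind of change already appears between two measured compounds: dimethylamino in place of trifluoromethyl on an aromatic carbon. The two places are not worded alike: in the measured pair the group sits para to a large group, whereas in the pair still to be measured it sits meta to a large group, so this is the same kind of change rather than the same change. Across the measured pair the step was a number no lower from compound 2 to compound 1 (the limit leaves the size open), and its size cannot be read because of the limit of > 25000 nM in this assay, at which 1 of the 3 values shown sits. The difference between the core of compound 2 and the core of compound 3 is not broken down here. The values of compound 2 and compound 3 lie within the usual scatter of each other.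

For compound 4 a step of about a 1.6-fold higher number from compound 3 to compound 4 (0.19 log units; within the scatter) is expected, resting on the measured step of a number no lower from compound 2 to compound 1 (the limit leaves the size open) and on the value of compound 3, 16000 nM. The estimate for compound 4 is therefore 25000 nM, with a range from 12000 nM to 60000 nM, and a fair chance that the assay again reports only a limit.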

Compound 4, half-maximal effective concentration: > 25000 nM
Compound 4: only a limit was reported (the forecaster's own chance of this, stated with the estimate: 50%); the middle value sits exactly at the limit.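

In this assay compound 4 gives > 25000 nM, which is a limit of the assay and not a number. Putting dimethylamino in place of trifluoromethyl gives an at least 1.5-fold higher number from compound 3 to compound 4 (0.19 log units; that floor lies within the scatter), so the floor of this step does not by itself show a real rise, and comparing it with the same swap on the other core gives no firm match or mismatch: the same change on two cores in this assay, a number no lower (the limit leaves the size open) from compound 2 to compound 1 and an at least 1.5-fold higher number (0.19 log units; that floor lies within the scatter) from compound 3 to compound 4; the limit leaves it open whether they differ What this does show is that the swap gave no lower number on either core, but it does not show a size that could be carried from one core to the other, and the exact steps cannot be read because the values of both dimethylamino compounds stop at the limit: the limit of > 25000 nM in this assay, at which 2 of the 4 values shown sit.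

As far as these compounds go, it remains open whether a carboxylic acid or a longer chain in the same place on the ring would give a number that can be read in this assay, and whether such a group would behave alike on both cores. From the compounds shown here alone, how far the true values of compound 1 and compound 4 lie past the limit also remains open, so a direct comparison of the two steps has still to be made.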